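Formyl for (propylamino)methyl: cytotoxicity at the limit

The source may hold more compounds than are shown below. What is called first, only, known or untested is meant among the compounds shown, and "the series" means these compounds.

Compound 1 `CC(C)N(Cc1cccc(OCCCCCC(=O)O)c1)C(=O)c1ccc(-c2ccc(Cl)c(Cl)c2)cc1`: > 26000 nM
Compound 2 `CC(C)N(Cc1cccc(OCCCCCC(=O)O)c1)C(=O)c1ccc(-c2cccc([N+](=O)[O-])c2)cc1`: > 26000 nM
Compound 3 `CCCNCc1ccccc1OCCCCCC(=O)OCC`: > 26000 nM

In an ADME assay on HEK293 cells (Homo sapiens) for cytotoxicity, read by CellTiter-Glo and resazurin assay, with a stated time of 72 h (on this read-out lower numbers stand for an effect already at smaller amounts and higher numbers for an effect only at larger amounts of compound), compound 1 reaches only a limit, > 26000 nM. Compound 2 likewise gives a limit, > 26000 nM. The step that the two limits leave unreadable from compound 1 to compound 2 is therefore not readable. Compound 3 also stands at a limit, > 26000 nM, and the picture is summed up by the limit of > 26000 nM in this assay, at which 3 of the 3 values shown sit. Compound 4 `CCOC(=O)CCCCCOc1ccccc1C=O` differs from compound 3 by formyl in place of (propylamino)methyl on an aromatic carbon. Among the measured compounds shown here, no measured step bears on this change, and the single step measured cannot be sized, so no step beyond the scatter is expected in this assay. Compound 4 is therefore expected at 40000 nM, within 15000 nM to 120000 nM. The expected step is a step that the limit leaves unreadable from compound 3 to compound 4.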

Compound 4, half-maximal effective concentration: > 26000 nM
Compound 4 ended at the assay's limit; the forecaster's own chance of this, stated with the estimate: 80%; the middle value lies beyond the limit too.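

Among the compounds shown here, compound 3 and compound 4 both stand only at a limit in this assay, so no step between them can be read. The compounds shown leave open at what concentration any of them would reach a half-maximal effect: the limit of > 26000 nM in this assay, at which 4 of the 4 values shown sit.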